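A Fluorine Joins the Methoxy Ring

This account rests on a few compounds, and the source may have more. Where it says the series, first, only, none or still open, it means among the compounds named here.

Compound 1 `CC(C)C[C@H](N)c1cc(C(F)(F)F)ccc1N1CCN(C(=O)C(C)Cc2ccc(Cl)cc2)CC1`: 47 nM
Compound 2 `CC(C)C[C@H](N)c1cc(C(F)(F)F)ccc1N1CCN(C(=O)COc2ccc(Cl)cc2)CC1`: 2900 nM
Compound 3 `COc1ccc(CC(C)C(=O)N2CCN(c3ccc(C(F)(F)F)cc3[C@@H](N)CC(C)C)CC2)cc1`: 120 nM

In an assay on HEK293 cells for displacement of a labelled ligand from Melanocortin receptor 4 (Homo sapiens) (on this read-out higher numbers stand for weaker inhibition and lower numbers for stronger inhibition), compound 3 gives 120 nM, the second highest of the three numbers: it is reached by a 2.6-fold higher number from compound 1 to compound 3 (0.41 log units; beyond the scatter) and by a 24-fold lower number from compound 2 to compound 3 (1.38 log units; beyond the scatter). Compound 4 `COc1ccc(CC(C)C(=O)N2CCN(c3ccc(C(F)(F)F)cc3[C@@H](N)CC(C)C)CC2)cc1F` differs from compound 3 in one place: fluoro in place of hydrogen on an aromatic carbon. Among the compounds with values here, no measured step adds a fluoro anywhere. The steps at hand either exchange the whole group on the carbonyl carbon, which gave the large 62-fold higher number from compound 1 to compound 2 (1.79 log units; beyond the scatter), or swap one ring substituent for another, which gave the modest 2.6-fold higher number from compound 1 to compound 3 (0.41 log units; beyond the scatter). Adding a single fluoro is a smaller alteration than either, so only a small step, likely within the scatter, is expected in this assay. Compound 4 is therefore estimated at 100 nM, between 40 nM and 300 nM, which corresponds to an expected 1.2-fold lower number from compound 3 to compound 4 (0.08 log units; within the scatter).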

Compound 4, inhibition constant: 200 nM
Compound 4: middle estimate off by 2.0-fold (0.30 log units), on the low side; the range from low to high includes it.
By their numbers in this assay, from the lowest: compound 1; then compounds 3 and 4 (each within the scatter of the next); then compound 2.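

In this assay, the first added fluoro gives a 1.7-fold higher number from compound 3 to compound 4 (0.22 log units; within the scatter), so this aromatic carbon, ortho to a methoxy group, takes the atom without a readable change. The large gap to the (4-chlorophenoxy)methyl group remains, at a 15-fold lower number from compound 2 to compound 4 (1.16 log units; beyond the scatter), and the 3-fluoro-4-methoxyphenyl group still differs from 4-chlorophenyl by a 4.3-fold higher number from compound 1 to compound 4 (0.63 log units; beyond the scatter). Nothing measured here gives a reason for this result. Open, from the compounds shown here alone, is whether a nitrile or a hydroxyl on this same carbon would also leave the number unchanged, and whether a fluoro on another carbon of this ring would.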